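Dimethylaminophenyl replacing hydroxyphenyl on the shared core

This account rests on a few compounds, and the source may have more. Where it says the series, first, only, none or still open, it means among the compounds named here.

Measured compounds:
- compound 1, `COc1cc(/C=C/C(=O)C2=C(/C=C/c3ccc(O)c(OC)c3)NC(=S)NC2c2ccccc2)ccc1O`: 26.5%
- compound 2, `COc1cc(/C=C/C(=O)C2=C(/C=C/c3ccc(O)c(OC)c3)NC(=S)NC2c2ccccc2O)ccc1O`: 60.2%

In a functional assay, with a stated time of 20 min, tested at 10 uM (a lower number here means a weaker effect, a higher number a stronger effect of the compound at the concentration tested), compound 2 stands highest of the two numbers; its nearest neighbour is compound 1, which in this assay gives 26.5%. Among the measured compounds shown here, the single measured step, a number 33.7 percentage points higher from compound 1 to compound 2 (beyond the scatter), came from placing a hydroxy where compound 1 had a hydrogen on an aromatic carbon.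

Compound 3, `COc1cc(/C=C/C(=O)C2=C(/C=C/c3ccc(O)c(OC)c3)NC(=S)NC2c2ccc(N(C)C)cc2)ccc1O`, differs from compound 2 in one place: 4-(dimethylamino)phenyl in place of 2-hydroxyphenyl on a saturated ring carbon. For the measured compounds named here, the group that enters carries no hydrogen-bond donor, so the one measured step bears on it in reverse: the hydroxy whose arrival gave the large gain is gone again. Nothing measured speaks to the 4-(dimethylamino)phenyl itself. The expected step is therefore a fall, a number 25.2 percentage points lower from compound 2 to compound 3 (beyond the scatter), back towards the level of compound 1, with wide uncertainty. Compound 3 is estimated at 35%, between 15% and 60%.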

Compound 3, a percentage reported as activity, at one concentration (the size of the read-out at that concentration, not a potency): 72%
The estimate for compound 3 lay 37 percentage points below the measured number; the measured number lies above the stated range.
By their numbers in this assay, from the lowest: compound 1; then compound 2; then compound 3.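

At this saturated ring carbon, a hydrogen-bond donor on the aromatic ring is not needed for a high number in this assay: exchanging 2-hydroxyphenyl for 4-(dimethylamino)phenyl, which has none, gives a number 11.8 percentage points higher from compound 2 to compound 3 (beyond the scatter). Measured against the plain phenyl, the 4-(dimethylamino)phenyl gives a number 45.5 percentage points higher from compound 1 to compound 3 (beyond the scatter), so both substituted phenyl groups shown read higher than the plain phenyl, and the gain seen with the hydroxy is not unique to that group. Nothing available explains why the group without a donor reads highest of the three.

The two names also put their groups at different numbered places on the phenyl, 2 against 4, so these compounds cannot separate the effect of the group from that of its place. From the compounds shown here alone, how a methoxy, a plain amine or a carboxylic acid on this phenyl would read remains open.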